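The compounds below may be only part of what the source reports. "The series", "measured", "known", "first", "only" and "open" are said of these compounds alone.

Working notes on the series. Compound 1 `CC(C)S(=O)(=O)NC(=O)c1ccc(Nc2nc(NC3(c4ccc(Cl)cc4)CC3)nc(OCC(F)(F)F)n2)cc1` and compound 2 `O=C(NS(=O)(=O)CCNC(=O)C1CC1)c1ccc(Nc2nc(NC3(c4ccc(Cl)cc4)CC3)nc(OCC(F)(F)F)n2)cc1` share one core. Within the data shown here, in an ADME assay on microsomes from liver (Homo sapiens) for metabolic stability, with a stated time of 10 min (a lower number here means that less of the compound is left, a higher number that more of the compound is left), compound 1 gives 100% and compound 2 gives 90%; the single measured step is a number 10 percentage points lower from compound 1 to compound 2 (within the scatter). Among the measured compounds shown here, compound 2 thus sits within the scatter of compound 1, the only other number available. Compound 3 `CC(C)OC(=O)NCCS(=O)(=O)NC(=O)c1ccc(Nc2nc(NC3(c4ccc(Cl)cc4)CC3)nc(OCC(F)(F)F)n2)cc1` differs from compound 2 by isopropoxy in place of cyclopropyl on a carbonyl carbon. For the measured compounds named here, no measured step covers this kind of change; the one step known, a number 10 percentage points lower from compound 1 to compound 2 (within the scatter), stayed within the scatter, so no step beyond the scatter is expected in this assay. Compound 3 is estimated at 90%, range 72% to 100%, which means an expected step of no change at the digits printed from compound 2 to compound 3 (within the scatter).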

Compound 3, percent of the compound remaining: 100%
Estimate against measurement, compound 3: 10 percentage points below; low and high end bracket the measured number.
By their numbers in this assay, from the lowest: compounds 2, 1 and 3 (each within the scatter of the next).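

In this assay, isopropoxy in place of cyclopropyl on a carbonyl carbon gives a number 10 percentage points higher from compound 2 to compound 3 (within the scatter), so at this position neither the ring nor the added oxygen produces a step beyond the scatter. With 2-((isopropoxycarbonyl)amino)ethyl in place of isopropyl on the sulfonyl sulfur, the reading is no change at the digits printed from compound 1 to compound 3 (within the scatter). Nothing on hand gives a reason for either step. The compounds shown leave open whether a free amine in place of the (isopropoxycarbonyl)amino group, or a carboxylic acid at the end of the chain on the sulfonyl sulfur, would also stay within the scatter.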